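The source may hold more compounds than are shown below. What is called first, only, known or untested is meant among the compounds shown, and "the series" means these compounds.

Of the compounds shown here, three built on one shared core have been measured in an ADME assay on Huh-7 cells (Homo sapiens) for cytotoxicity; a lower number here means that less compound is tolerated, a higher number that more compound is tolerated. Compound 1 `O=C(NC(=S)N1CCc2c(OCCCCCOc3ccc(Cl)cc3)cccc21)c1ccc(F)cc1` gives 31100 nM. Compound 2 `COc1ccc(C(=O)NC(=S)N2CCc3c(OCCCCCOc4ccc(Cl)cc4)cccc32)cc1`, which differs only in carrying a methoxy group in place of the fluoro on an aromatic carbon, gives 34400 nM; the step of a 1.1-fold higher number from compound 1 to compound 2 (0.04 log units; within the scatter). Compound 3 `CN(C)c1ccc(C(=O)NC(=S)N2CCc3c(OCCCCCOc4ccc(Cl)cc4)cccc32)cc1` carries a dimethylamino group on that aromatic carbon instead. For compound 3 the assay reports only a limit, > 50000 nM, and not a number. Compound 3 thus stands at the limit of > 50000 nM in this assay, at which 1 of the 3 values shown sits, so its steps from the other two are floors only: an at least 1.6-fold higher number from compound 1 to compound 3 (0.20 log units; that floor lies within the scatter) and an at least 1.4-fold higher number from compound 2 to compound 3 (0.16 log units; that floor lies within the scatter).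

Compound 4 `O=C(NC(=S)N1CCc2c(OCCCCCOc3ccc(Cl)cc3)cccc21)C1CCCC1` has not yet been measured. Its change from compound 3 is cyclopentyl in place of 4-(dimethylamino)phenyl on a carbonyl carbon. None of the three measured steps touches this place; each of them swapped one group on the aromatic ring, and none of them was shown to move beyond the scatter. Among the measured compounds shown here, no measured step therefore speaks directly to a change at the carbonyl carbon, and the three values so far sit close together or at the limit. The step of an at least 1.2-fold lower number from compound 3 to compound 4 (0.09 log units; that floor lies within the scatter) is therefore expected to be small. Compound 4 is estimated at 40000 nM, with a likely range from 18000 nM to 90000 nM.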

Compound 4, half-maximal cytotoxic concentration: > 50000 nM
Compound 4 ended at the assay's limit; the forecaster's own chance of this, stated with the estimate: 40%; middle value at least 1.2-fold (0.09 log units) away from the limit.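

Among the compounds shown here, compound 4 brings the first change at the carbonyl carbon rather than on the aromatic ring, and with cyclopentyl in place of 4-(dimethylamino)phenyl it stands where compound 3 stands in this assay: the limit of > 50000 nM in this assay, at which 2 of the 4 values shown sit. Among these compounds, then, an aromatic ring on the carbonyl carbon is not needed to reach this limit, since a non-aromatic ring of carbon only reaches it too. The comparisons with the other two compounds give an at least 1.4-fold higher number from compound 2 to compound 4 (0.16 log units; that floor lies within the scatter) and an at least 1.6-fold higher number from compound 1 to compound 4 (0.20 log units; that floor lies within the scatter), so neither shows a change beyond the scatter, and the step between the two compounds at the limit cannot be read.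

As far as these compounds go, it remains open whether a methyl group, an open hexyl chain or a nitrogen-containing ring such as piperidinyl on that carbonyl carbon would give a number clearly apart from these. Also open, from the compounds shown here alone, is how far the true values of compound 3 and compound 4 lie beyond the limit, so these two compounds cannot be placed in any order.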